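The source may report more compounds than this note shows. Statements on the series, on what has been measured and on what is new or still open speak of the compounds shown alone.

Measured compounds in an assay on isolated protein for inhibition of glutathione S-transferase P (Homo sapiens), with a stated time of 10 min; a higher number here means a weaker inhibitor, a lower number a stronger inhibitor:
- compound 1 `O=C(CCC(=O)OCCCCCCSc1ccc([N+](=O)[O-])c2nonc12)Nc1ccccc1`: 10200 nM
- compound 2 `O=C(CCC(=O)OCCCCCCSc1ccc([N+](=O)[O-])c2nonc12)Nc1ccccc1Cl`: 15500 nM
- compound 3 `O=C(CCC(=O)OCCCCCCSc1ccc([N+](=O)[O-])c2nonc12)Nc1ccc(C(F)(F)F)cc1`: 5050 nM

Compound 1 sits second highest of the three numbers. Its nearest neighbour is compound 2, the step of a 1.5-fold higher number from compound 1 to compound 2 (0.18 log units; within the scatter) lying within the scatter; its furthest is compound 3, reached by a 2.0-fold lower number from compound 1 to compound 3 (0.31 log units; beyond the scatter). Both of those steps, and a 3.1-fold lower number from compound 2 to compound 3 (0.49 log units; beyond the scatter), alter only what is attached to the aromatic ring of the anilino group, and none of them is large.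

Compound 4 `O=C(CCC(=O)N1CCCCC1)OCCCCCCSc1ccc([N+](=O)[O-])c2nonc12` is not yet measured. It differs from compound 1 by piperidin-1-yl in place of anilino on a carbonyl carbon. Among the measured compounds shown here, no measured step touches this position: every change so far keeps the anilino group and varies its ring, so there is no direct precedent for removing it. For the measured compounds named here, the only guidance is that the measured steps at the neighbouring position stayed modest, which gives no ground to expect a large move in either direction.

The estimate for compound 4 is therefore 12000 nM, with a range of 4500 nM to 32000 nM, meaning an expected step of a 1.2-fold higher number from compound 1 to compound 4 (0.07 log units; within the scatter) that is not confidently distinguished from the scatter.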

Compound 4, half-maximal inhibitory concentration: 500 nM
Beside the measured number, compound 4's estimate is 24-fold (1.38 log units) above it, outside the stated range (below it).
By their numbers in this assay, from the lowest: compound 4; then compound 3; then compounds 1 and 2 (each within the scatter of the next).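

In this assay, the group on the carbonyl carbon matters far more than the substitution on the anilino ring: a 20-fold lower number from compound 1 to compound 4 (1.31 log units; beyond the scatter) is larger than any step among the anilino compounds. The advantage of piperidin-1-yl holds against both substituted anilino compounds, with a 10-fold lower number from compound 3 to compound 4 (1.00 log units; beyond the scatter) and a 31-fold lower number from compound 2 to compound 4 (1.49 log units; beyond the scatter), and the change removes the aromatic ring and the hydrogen-bond donor together. Nothing available explains the lower number.

These compounds do not separate the loss of the aromatic ring from the loss of the amide hydrogen: cyclohexylamino would keep that hydrogen without the aromatic ring, while N-methylanilino would keep the aromatic ring without the hydrogen. Going by these compounds, how specific the gain is to piperidin-1-yl also remains open, as pyrrolidine and morpholine amides would show.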